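This account rests on a few compounds, and the source may have more. Where it says the series, first, only, none or still open, it means among the compounds named here.

Compound 3 `O=C([C@@H]1C[C@H]1F)N1CC2CC(C1)N2` is one of three amides that share a common core and differ only in the group on the carbonyl carbon. In an assay on SH-EP1 cells for agonist activity at Neuronal acetylcholine receptor; alpha4/beta2 (Homo sapiens), read by FLIPR and calcium flux (a higher number here means a larger maximal response, a lower number a smaller maximal response), compound 3 gives 110%, which places it level with compound 1 `CCC(=O)N1CC2CC(C1)N2`, whose value is 110%; together the two are the highest of the three numbers, while compound 2 `CC(C)C(=O)N1CC2CC(C1)N2` with 71% lies furthest away. The step of no change at the digits printed from compound 1 to compound 3 (within the scatter) was within the scatter, whereas the step of a number 39 percentage points lower from compound 1 to compound 2 (beyond the scatter) and the step of a number 39 percentage points higher from compound 2 to compound 3 (beyond the scatter) were both large.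

Compound 4 `C[C@@H]1C[C@@H]1C(=O)N1CC2CC(C1)N2` is not yet measured. It differs from compound 3 in one place: a group of 4 heavy atoms (4 carbon; one three-membered non-aromatic ring of carbon only) in place of a group of 4 heavy atoms (3 carbon, 1 fluorine; one three-membered non-aromatic ring of carbon only), on a carbonyl carbon. Among the measured compounds shown here, no measured step exchanges fluorine for carbon on the three-membered ring, so the nearest guides are the step of no change at the digits printed from compound 1 to compound 3 (within the scatter), where 2-fluorocyclopropyl in place of ethyl left the maximal response unchanged, and the step of a number 39 percentage points lower from compound 1 to compound 2 (beyond the scatter), where methyl in place of hydrogen on a saturated chain carbon bound to a carbonyl carbon brought a large fall. The expected step is a number 10 percentage points lower from compound 3 to compound 4 (within the scatter), at most a small fall that may stay within the scatter. Compound 4 is estimated to give about 100% in this assay, between 75% and 120%.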

Compound 4, largest response reached (Emax), in percent of the reference or control that the assay uses: 97%
Estimate against measurement, compound 4: 3 percentage points above; the measured number falls inside the stated range.
By their numbers in this assay, from the lowest: compound 2; then compound 4; then compounds 1 and 3 (each within the scatter of the next).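

On the carbonyl carbon, carbon and fluorine in the group with a three-membered ring are not interchangeable in this assay: the change gives a number 13 percentage points lower from compound 3 to compound 4 (beyond the scatter), a modest step beyond the scatter. The all-carbon group also separates compound 4 from both open-chain amides, with a number 13 percentage points lower from compound 1 to compound 4 (beyond the scatter) and a number 26 percentage points higher from compound 2 to compound 4 (beyond the scatter), so compound 4 takes an intermediate place, and a three-membered ring alone does not set the maximal response, since compound 3 and compound 4 both carry one and still differ. Nothing shown here gives a reason for these differences.

As far as these compounds go, with only 2-fluorocyclopropyl and the all-carbon group of compound 4 to compare, it remains open how unsubstituted cyclopropyl, a hydroxyl or a nitrile on the ring, or a longer chain such as butyl would behave at this carbonyl carbon. Each ring group also appears with a single set of defined stereocentres, which leaves the response of its other stereoisomers unknown.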